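A few compounds are considered here, and "the series" means these few. Any claim that something is new, unique, unknown or untested is made for them only; others in the source may bear on it.

Two compounds share one core and differ only in the group on an oxygen next to a carbonyl group. In an assay on membranes from HEK293 cells for displacement of a labelled ligand from adenosine receptor A2b (Homo sapiens), read by scintillation counting, with a stated time of 30 min, tested at 1 uM (a higher number here means more inhibition at the concentration tested (going by the name of the read-out), a lower number less inhibition), compound 1 `COC(=O)C1=C(C)NC(=O)NC1c1cccs1` gives 19%, and compound 2 `CCC(CC)OC(=O)C1=C(C)NC(=O)NC1c1cccs1` gives 6%, the lowest of the two numbers shown, with compound 1 nearest. Going by the values given here, the single measured step, a number 13 percentage points lower from compound 1 to compound 2 (beyond the scatter), changed that same oxygen-bound group. Compound 3 `CC1=C(C(=O)OC2CCCCC2)C(c2cccs2)NC(=O)N1` changes it again: cyclohexyl in place of pentan-3-yl on an oxygen next to a carbonyl group. Among the compounds with values here, with only that one step to go by, compound 3 is expected to sit close to compound 2, a step of no change at the digits printed from compound 2 to compound 3 (within the scatter) in this assay, within the scatter, and its estimated value is 6%, ranging from -8% to 20%.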

Compound 3, a percentage reported as inhibition, at one concentration (the size of the read-out at that concentration, not a potency): 3%
Compound 3: the middle estimate sits 3 percentage points above what was measured, within the range that was stated.
By their numbers in this assay, from the lowest: compounds 3 and 2 (each within the scatter of the next); then compound 1.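

In this assay, swapping the open pentan-3-yl for a cyclohexyl ring on this oxygen gives a number 3 percentage points lower from compound 2 to compound 3 (within the scatter), so the ring adds no readable difference. Set against methyl, cyclohexyl gives a number 16 percentage points lower from compound 1 to compound 3 (beyond the scatter), so a second, differently shaped carbon group also falls beyond the scatter from compound 1. Nothing available explains these numbers.

Still open, going by these compounds, is where the number would fall with an ethyl group on this oxygen, between methyl and these larger groups. A chain ending in an amine could also read differently, since every group here is carbon only.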